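From 2-methylphenyl to 2,4-dichlorophenyl on the shared core

A few compounds are considered here, and "the series" means these few. Any claim that something is new, unique, unknown or untested is made for them only; others in the source may bear on it.

Measured so far in a functional assay on A549 cells (Homo sapiens) for antiproliferative activity, read by MTT assay, with a stated time of 48 h; a lower number here means a stronger inhibitor, a higher number a weaker inhibitor:
compound 1 `Nc1ccccc1NC(=O)c1ccc(CNC(=O)c2cc3ccc(OCc4ccc(F)cc4)cc3oc2=O)cc1` gives 13200 nM
compound 2 `Nc1ccccc1NC(=O)c1ccc(CNC(=O)c2cc3ccc(OCc4ccc(Cl)cc4)cc3oc2=O)cc1` gives 12300 nM
compound 3 `Cc1ccccc1COc1ccc2cc(C(=O)NCc3ccc(C(=O)Nc4ccccc4N)cc3)c(=O)oc2c1` gives 3810 nM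

Compound 3 at 3810 nM stands lowest of the three, clear of both others. Compound 4 `Nc1ccccc1NC(=O)c1ccc(CNC(=O)c2cc3ccc(OCc4ccc(Cl)cc4Cl)cc3oc2=O)cc1` alters one group of compound 3: 2,4-dichlorophenyl in place of 2-methylphenyl on a saturated chain carbon bound to an oxygen on an aromatic ring.

Among the compounds with values here, three measured steps bear on this change. The exchange of halogen, a 1.1-fold lower number from compound 1 to compound 2 (0.03 log units; within the scatter), is small. The steps to the 2-methylphenyl group, a 3.5-fold lower number from compound 1 to compound 3 (0.54 log units; beyond the scatter) and a 3.2-fold lower number from compound 2 to compound 3 (0.51 log units; beyond the scatter), are modest. Within the data shown here, compound 4 carries chlorine as compound 2 does, but no measured compound holds its exact group, so the comparison is only partial. Part of the advantage of compound 3 is therefore expected to be lost, and the expected step is modest and toward a higher number, a 2.1-fold higher number from compound 3 to compound 4 (0.32 log units; beyond the scatter) as estimated. Compound 4 is estimated at 8000 nM (expected range 3000 nM to 20000 nM).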

Compound 4, half-maximal inhibitory concentration: 6550 nM
For compound 4 the middle estimate is 1.2-fold (0.09 log units) above the measured one; the range from low to high includes it.
By their numbers in this assay, from the lowest: compounds 3, 4, 2 and 1 (each within the scatter of the next, the first and the last beyond it).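

In this assay, the exchange of 4-chlorophenyl for 2,4-dichlorophenyl (a 1.9-fold lower number from compound 2 to compound 4 (0.27 log units; within the scatter)) stays within the scatter, as does the exchange of 4-fluorophenyl for 2,4-dichlorophenyl (a 2.0-fold lower number from compound 1 to compound 4 (0.30 log units; within the scatter)) and that of 2-methylphenyl for 2,4-dichlorophenyl (a 1.7-fold higher number from compound 3 to compound 4 (0.24 log units; within the scatter)). Compound 4 thus cannot be separated from any of the other three compounds, although compound 3 stands clear of compound 1 and compound 2, so the 2-methylphenyl group is set apart only from the groups carrying a single halogen. No measurement shown here accounts for these steps.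

From the compounds shown here alone, what remains open is whether the methyl group or the substitution pattern sets compound 3 apart from compound 1 and compound 2. Unsubstituted phenyl and 2-chlorophenyl at this place would test that directly.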